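Chloro on the pendant ring: cytotoxicity of a thiosemicarbazone pair

The source may hold more compounds than are shown below. What is called first, only, known or untested is meant among the compounds shown, and "the series" means these compounds.

Compound 1 `CC(=O)c1ccc2[nH]c(-c3ccccc3)nc2c1` and compound 2 `CC(=O)c1ccc2[nH]c(-c3ccc(Cl)cc3)nc2c1` carry an acetyl group on the shared core; compound 3 `C/C(=N\NC(N)=S)c1ccc2[nH]c(-c3ccccc3)nc2c1` and the not yet measured compound 4 `C/C(=N\NC(N)=S)c1ccc2[nH]c(-c3ccc(Cl)cc3)nc2c1` carry the larger thiosemicarbazone-type group instead. In an ADME assay on MDBK cells (Bos taurus) for cytotoxicity, read by MTT assay, with a stated time of 96 h (a lower number here means that less compound is tolerated, a higher number that more compound is tolerated), compound 1 gives only a limit, > 100000 nM. Compound 2 likewise gives only a limit in this assay, > 100000 nM. Within the data shown here, compound 3 is the only one with a number in this assay, 32000 nM.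

The change from compound 1 to compound 2 is chloro in place of hydrogen on an aromatic carbon; its step, a step that the two limits leave unreadable from compound 1 to compound 2, cannot be read because both values sit at the limit of > 100000 nM in this assay, at which 2 of the 3 values shown sit. The two cores differ by a group of 7 heavy atoms (3 carbon, 3 nitrogen, 1 sulfur; no ring) in place of a group of 3 heavy atoms (2 carbon, 1 oxygen; no ring), on an aromatic carbon, and that step is an at least 3.1-fold lower number from compound 1 to compound 3 (0.49 log units; beyond the scatter). The change from compound 3 to compound 4 is chloro in place of hydrogen on an aromatic carbon, the same change, at the same place as before.

With the earlier step unreadable, the expectation for compound 4 rests on compound 3 at 32000 nM and assumes little movement: the expected step is a 1.3-fold lower number from compound 3 to compound 4 (0.11 log units; within the scatter). Compound 4 is therefore estimated at 25000 nM, within 8000 nM to 80000 nM.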

Compound 4, half-maximal cytotoxic concentration: > 100000 nM
Compound 4 gave a limit, no number; the forecaster's own chance of this, stated with the estimate: 10%; middle value at least 4.0-fold (0.60 log units) away from the limit.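

On the core of compound 3, which carries the thiosemicarbazone-type group, phenyl to 4-chlorophenyl gives an at least 3.1-fold higher number from compound 3 to compound 4 (0.49 log units; beyond the scatter) in this assay. The steps from compound 1 to compound 2 and from compound 2 to compound 4 cannot be read, as both values in each pair sit at the same limit: the limit of > 100000 nM in this assay, at which 3 of the 4 values shown sit. The series therefore neither confirms nor refutes that the change carries from one core to the other, and the full size of the step from the thiosemicarbazone-type compound is not given, only its minimum.

Going by these compounds, whether chloro in place of hydrogen moves the number in the same direction on any further core remains open, as a single readable pair defines no trend. On these data alone, it is also open whether an amine, a methoxy group or a carboxylic acid at this same place on the pendant ring would behave as chloro does.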